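Ether-chain length and cytotoxicity in a hindered phenol series

This account rests on a few compounds, and the source may have more. Where it says the series, first, only, none or still open, it means among the compounds named here.

Compound 1 `COCCOCCOCCOCC(=O)Oc1c(C(C)C)cccc1C(C)C` carries a methoxy-capped ether chain on the ester side of the shared core. Going by the values given here, in an ADME assay on A549 cells (Homo sapiens) for cytotoxicity, read by MTT assay, with a stated time of 24 h (on this read-out lower numbers stand for an effect already at smaller amounts and higher numbers for an effect only at larger amounts of compound), compound 1 gives 740000 nM, one of only two numbers in the set. Compound 2 `COCCOCCOCCOCCOCCOCCOCCOC(=O)Oc1c(C(C)C)cccc1C(C)C`, a longer-chain carbonate, gives 500000 nM in this assay, which lies within the scatter of compound 1. Compound 3 `COCCOCCOC(=O)Oc1c(C(C)C)cccc1C(C)C`, the shortest carbonate, sits at a limit of this assay rather than a number, > 10000000 nM (the limit of > 10000000 nM in this assay, at which 1 of the 3 values shown sits). Compound 4 `COCCOCCOCC(=O)Oc1c(C(C)C)cccc1C(C)C` remains to be measured: hydrogen in place of methoxymethyl on a saturated chain carbon bound to an oxygen on a saturated carbon. Among the compounds with values here, no measured pair shows this step. The shortest chain, compound 3, reaches the limit, so a move toward a higher number is the working expectation. The step from compound 1 to compound 4 is expected to be a 2.0-fold higher number from compound 1 to compound 4 (0.31 log units; beyond the scatter). Compound 4 is estimated at 1500000 nM, with a range of 400000 nM to 10000000 nM.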

Compound 4, half-maximal effective concentration: 4150000 nM
Beside the measured number, compound 4's estimate is 2.8-fold (0.44 log units) below it, within the range that was stated.
By their numbers in this assay, from the lowest: compounds 2 and 1 (each within the scatter of the next); then compound 4. At a limit, above all of these: compound 3.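

Hydrogen in place of methoxymethyl on a saturated chain carbon bound to an oxygen on a saturated carbon gives a 5.6-fold higher number from compound 1 to compound 4 (0.75 log units; beyond the scatter) in this assay. Going by these compounds alone, this is the first step that can be read at this position, and it lies beyond the scatter, so removing methoxymethyl here does change the read-out. The finding rests on this single pair.

Going by these compounds, what a longer chain or an amine at the chain end would do at this position remains open. Compound 3 stands at a limit, not a number, and how far it lies from the measured values cannot be read: the limit of > 10000000 nM in this assay, at which 1 of the 4 values shown sits.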